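Compound 2 to compound 4: methoxymethyl to hydroxymethyl

This account rests on a few compounds, and the source may have more. Where it says the series, first, only, none or still open, it means among the compounds named here.

In a functional assay on MCF7 cells (Homo sapiens) for antiproliferative activity, read by MTT assay, with a stated time of 48 h (a lower number here means a stronger inhibitor, a higher number a weaker inhibitor), compound 1 (`CC(=O)OC/C1=C/C[C@](C)(CCC=C(C)C)/C=C/[C@@H](OC(=O)C=C(C)C)[C@](C)(O)/C=C/C1=O`) gives 4510 nM, compound 3 (`COC/C1=C/C[C@](C)(CCC=C(C)C)/C=C/[C@@H](OC(=O)C=C(C)C)[C@](C)(O)/C=C/C1=O`) gives 4130 nM, and compound 2 (`COC/C1=C/C[C@](C)(CCC=C(C)C)/C=C/[C@@H](OC(=O)C=C(C)C)[C@](C)(OC)/C=C/C1=O`) stands highest of the three at 16500 nM. Compound 4 (`CO[C@]1(C)/C=C/C(=O)/C(CO)=C\C[C@](C)(CCC=C(C)C)/C=C/[C@H]1OC(=O)C=C(C)C`) is reached from compound 2 by hydrogen in place of methyl on an oxygen on a saturated carbon, methoxymethyl to hydroxymethyl. The larger measured step, a 4.0-fold lower number from compound 2 to compound 3 (0.60 log units; beyond the scatter), removes the other methyl on oxygen and leaves methoxymethyl in place, so it bears only indirectly. Among the compounds with values here, the step at this same group, a 1.1-fold lower number from compound 1 to compound 3 (0.04 log units; within the scatter), exchanges acetyl for methyl, though no measured compound carries free hydroxymethyl. The expected change in this assay is therefore small, a 1.5-fold lower number from compound 2 to compound 4 (0.18 log units; within the scatter), with no shift beyond the scatter. For compound 4 the estimated value is 11000 nM, with an expected range of 4500 nM to 25000 nM.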

Compound 4, half-maximal inhibitory concentration: 14300 nM
Compound 4: the middle estimate sits 1.3-fold (0.11 log units) below what was measured; the measured number falls inside the stated range.
By their numbers in this assay, from the lowest: compounds 3 and 1 (each within the scatter of the next); then compounds 4 and 2 (each within the scatter of the next).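

Free hydroxymethyl, new to the series, reads in this assay as a 1.2-fold lower number from compound 2 to compound 4 (0.06 log units; within the scatter), so methoxymethyl and hydroxymethyl are not told apart here. The same exchange on the other methoxy group, a 4.0-fold lower number from compound 2 to compound 3 (0.60 log units; beyond the scatter), lies beyond the scatter, so the two oxygens do not answer alike when changed from compound 2. Nothing available accounts for this difference between the two sites.

Still open, going by these compounds, is whether an amine or a carboxylic acid in place of the hydroxy, or a longer chain on this oxygen, would shift the number beyond the scatter.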